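The source may hold more compounds than are shown below. What is called first, only, known or untested is meant among the compounds shown, and "the series" means these compounds.

Measured compounds:
- compound 1, `O=C(Nc1ccc(Oc2ccnc3[nH]ccc23)cc1)c1nn(-c2ccc(Br)cc2F)ccc1=O`: 46400 nM
- compound 2, `O=C(Nc1ccc(Oc2ccnc3[nH]ccc23)cc1)c1nn(-c2ccc(Cl)c(C(F)(F)F)c2)ccc1=O`: 1320 nM

Compound 1 gives the highest of the two numbers recorded in a functional assay on HepG2 cells (Homo sapiens) for cytotoxicity, read by MTT assay, with a stated time of 72 h; a lower number here means a stronger inhibitor, a higher number a weaker inhibitor; its nearest neighbour is compound 2, reached by a 35-fold lower number from compound 1 to compound 2 (1.55 log units; beyond the scatter), a change on the aryl group attached to the pyridazinone nitrogen. The compound now under consideration is compound 3, `Cn1ccc2c(Oc3ccc(NC(=O)c4nn(-c5ccc(Br)cc5F)ccc4=O)cc3)ccnc21`. Within the data shown here, it differs from compound 1 by methyl in place of hydrogen on an aromatic nitrogen, a change at a different part of the shared core from the one varied between compound 1 and compound 2. Among the measured compounds shown here, no measured step touches this position, so the only pair available, the large step from compound 1 to compound 2, does not bear on it directly and gives no guide to its direction. For the measured compounds named here, with no comparable step recorded, the expectation is a step of a 1.1-fold higher number from compound 1 to compound 3 (0.03 log units; within the scatter), that is, a number close to that of compound 1 and likely within the scatter. Compound 3 is accordingly estimated at 50000 nM in this assay, with a range from 15000 nM to 170000 nM.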

Compound 3, half-maximal inhibitory concentration: 31200 nM
Compound 3: the middle estimate sits 1.6-fold (0.20 log units) above what was measured, and the stated range covers the measured number.
By their numbers in this assay, from the lowest: compound 2; then compounds 3 and 1 (each within the scatter of the next).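

In this assay, a 1.5-fold lower number from compound 1 to compound 3 (0.17 log units; within the scatter) stays within the scatter, so with the 4-bromo-2-fluorophenyl group held fixed, the numbers for the two compounds cannot be told apart. Among these compounds, this is the first reading at this position, an aromatic nitrogen of a five-membered aromatic ring with 1 nitrogen, and it shows that methyl in place of hydrogen here makes no difference that this assay can resolve, in contrast to the aryl group on the other aromatic nitrogen, where a 35-fold lower number from compound 1 to compound 2 (1.55 log units; beyond the scatter) lies beyond the scatter. No measurement offered here accounts for this result.

The compounds shown leave open whether methyl on this nitrogen would read the same alongside the 4-chloro-3-(trifluoromethyl)phenyl group, since the single step at this position carries the 4-bromo-2-fluorophenyl group. They also leave open whether this nitrogen would give a similar number with something other than methyl on it, such as a longer chain like propyl, a chain ending in an amine, or one ending in a carboxylic acid.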